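Methyl on the hydroxy group of compound 1

The source may hold more compounds than are shown below. What is called first, only, known or untested is meant among the compounds shown, and "the series" means these compounds.

Within the data shown here, in a functional assay on RXF 393 cells (Homo sapiens) for antiproliferative activity, read by sulforhodamine B assay, with a stated time of 48 h (a lower number here means a stronger inhibitor of growth, a higher number a weaker inhibitor of growth), compound 1 `O=C(NCCCNc1cc(-c2cn(-c3ccccc3)nc2-c2cccc(O)c2)ccn1)Nc1ccc(F)cc1` gives 4850 nM and compound 2 `O=C(NCCCNc1cc(-c2cn(-c3ccccc3)nc2-c2cccc(O)c2)ccn1)Nc1cccc(C(F)(F)F)c1` gives 4960 nM, so compound 1 stands level with its only measured neighbour. Compound 3 `COc1cccc(-c2nn(-c3ccccc3)cc2-c2ccnc(NCCCNC(=O)Nc3ccc(F)cc3)c2)c1` turns 3-hydroxyphenyl into 3-methoxyphenyl, with methyl in place of hydrogen on an oxygen on an aromatic ring. Among the measured compounds shown here, the single measured step, a 1.0-fold higher number from compound 1 to compound 2 (0.01 log units; within the scatter), swaps 4-fluorophenyl for 3-(trifluoromethyl)phenyl on an amide-type nitrogen, elsewhere in the molecule, and no measured step touches the hydroxy group. A change beyond the scatter is therefore not expected, though this rests on thin evidence. The expected step is a 1.1-fold higher number from compound 1 to compound 3 (0.05 log units; within the scatter). For compound 3 the estimated value is 5500 nM, within an expected range of 2500 nM to 12000 nM.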

Compound 3, concentration for total growth inhibition: 28600 nM
For compound 3 the middle estimate is 5.2-fold (0.72 log units) below the measured one, and the stated range ends below it.
By their numbers in this assay, from the lowest: compounds 1 and 2 (each within the scatter of the next); then compound 3.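

Unlike the swap on the amide-type nitrogen, which stayed within the scatter, a change at the hydroxy group does register in this assay: methyl in place of hydrogen on the oxygen gives a 5.9-fold higher number from compound 1 to compound 3 (0.77 log units; beyond the scatter) and so marks this position as responsive to a single added carbon. Of this pair, the free hydroxy form holds the lower number. No evidence on hand accounts for the rise. On these data alone, whether the methyl itself or the missing hydrogen matters remains open. So does what an amine or a longer ethoxy group would give here.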